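A few compounds are considered here, and "the series" means these few. Any claim that something is new, unique, unknown or untested is made for them only; others in the source may bear on it.

Among the compounds with values here, compound 1 `Cc1ccc(-c2cs/c(=N/NC(=O)CSc3nnnn3-c3ccccc3)n2-c2ccccc2)cc1` stands lowest of the two numbers so far in a functional assay on C6 cells (Rattus norvegicus) for cytotoxicity, read by MTT assay, with a stated time of 24 h, tested at 25 ug/mL (a higher number here means a weaker effect of the compound at the concentration tested, a lower number a stronger effect), where compound 1 gives 38.8%. Within the data shown here, its nearest neighbour is compound 2 `O=C(CSc1nnnn1-c1ccccc1)N/N=c1/scc(-c2ccc(F)cc2)n1-c1ccccc1`, which in this assay gives 49.3%; the single step between them, fluoro in place of methyl on an aromatic carbon, read a number 10.5 percentage points higher from compound 1 to compound 2 (beyond the scatter). Compound 3 `Cc1ccc(-c2cs/c(=N/NC(=O)CSc3nnnn3C)n2-c2ccccc2)cc1` differs from compound 1 at another place altogether: methyl in place of phenyl on an aromatic nitrogen. Among the measured compounds shown here, no measured step touches that part of the shared core, so the one step known, from compound 1 to compound 2, does not bear on this change and gives no guide to its direction or size. With nothing pointing either way, the step of a number 1.2 percentage points higher from compound 1 to compound 3 (within the scatter) is expected to lie within the scatter. Compound 3 is therefore estimated in this assay at 40%, with a range from 25% to 60%.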

Compound 3, a percentage reported as activity, at one concentration (the size of the read-out at that concentration, not a potency): 60.7%
Compound 3: middle estimate off by 20.7 percentage points, on the low side; measured number outside the range, above it.
By their numbers in this assay, from the lowest: compound 1; then compound 2; then compound 3.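

In this assay, the nitrogen of the five-membered aromatic ring with 4 nitrogen proves to be a place that matters: the change from 1-phenyl-1H-tetrazol-5-yl to 1-methyl-1H-tetrazol-5-yl gives a number 21.9 percentage points higher from compound 1 to compound 3 (beyond the scatter), so the effect of the compound at the concentration tested is weaker with methyl. The earlier compounds had shown only a change on an aromatic carbon, and this is the first step to show that the group on this nitrogen also affects the read-out. Nothing measured here explains the shift.

The compounds shown leave open whether a ring is needed on this nitrogen or whether a chain such as propyl, or a benzyl group, would stand nearer to phenyl or to methyl. They also leave open whether a chloro or methoxy group on that phenyl would move the number in either direction.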